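The compounds below may be only part of what the source reports. "The series", "measured", "known", "first", "only" and "open" are said of these compounds alone.

In a functional assay on MCF-10A cells (Homo sapiens) for antiproliferative activity, with a stated time of 48 h (a lower number here means that less compound is needed, a higher number that more compound is needed for the effect), compound 1 `COc1ccc2nc(C)cc(NCc3ccccc3)c2c1` gives 25900 nM, compound 2 `COc1ccc2nc(C)cc(NCc3cccc(F)c3)c2c1` gives 11300 nM, and compound 3 `COc1cccc(CNc2cc(C)nc3ccc(OC)cc23)c1` gives 9700 nM. Compound 3 therefore sits level with compound 2, as a 1.2-fold lower number from compound 2 to compound 3 (0.07 log units; within the scatter) shows, and both have lower numbers than compound 1. Compound 4 `COc1ccc2nc(C)cc(NCc3cccc(OC(F)F)c3)c2c1` carries difluoromethyl in place of methyl on an oxygen on an aromatic ring. Among the measured compounds shown here, no measured step alters that methyl directly. The closest evidence is modest: a 2.3-fold lower number from compound 1 to compound 2 (0.36 log units; beyond the scatter) and a 2.7-fold lower number from compound 1 to compound 3 (0.43 log units; beyond the scatter). Swapping one of these groups for the other stayed within the scatter, so no shift beyond the scatter is expected in this assay. The expected step is a 1.1-fold lower number from compound 3 to compound 4 (0.03 log units; within the scatter). The estimate for compound 4 is 9000 nM, with a range from 4500 nM to 18000 nM.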

Compound 4, half-maximal effective concentration: 10300 nM
Compound 4: middle estimate off by 1.1-fold (0.06 log units), on the low side, and the stated range covers the measured number.
By their numbers in this assay, from the lowest: compounds 3, 4 and 2 (each within the scatter of the next); then compound 1.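

In this assay, difluoromethyl in place of methyl on the oxygen changes little, with a 1.1-fold higher number from compound 3 to compound 4 (0.03 log units; within the scatter). Difluoromethoxy also reads level with fluoro, at a 1.1-fold lower number from compound 2 to compound 4 (0.04 log units; within the scatter), while the comparison with hydrogen gives a 2.5-fold lower number from compound 1 to compound 4 (0.40 log units; beyond the scatter), so all three groups now shown at this place give a modest drop from the unsubstituted compound and cannot be told apart from one another. No measurement at hand explains why these groups read alike. Still open, on these data alone, is whether an amine or a carboxylic acid at this place would keep that level, and whether a longer chain on the oxygen would.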